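Cytotoxicity of indole acrylonitriles: a thiophene-to-chlorophenyl step

The source may report more compounds than this note shows. Statements on the series, on what has been measured and on what is new or still open speak of the compounds shown alone.

Measured so far:
compound 1, `COc1ccc(-c2[nH]c3ccc(OC)cc3c2/C=C(\C#N)S(=O)(=O)c2ccccc2)cc1`, 22000 nM
compound 2, `N#C/C(=C\c1c(-c2ccccc2)[nH]c2ccccc12)C(=O)c1cccs1`, 20000 nM

In an ADME assay on MRC5 cells (Homo sapiens) for cytotoxicity, read by MTT assay, with a stated time of 96 h (on this read-out higher numbers stand for an effect only at larger amounts of compound and lower numbers for an effect already at smaller amounts), compound 2 gives 20000 nM, and compound 1 gives 22000 nM; the two numbers lie within the usual scatter of one another, so nothing separates them. Compound 3, `N#C/C(=C\c1c(-c2ccccc2)[nH]c2ccccc12)C(=O)c1ccc(Cl)cc1`, has not been measured. It differs from compound 2 by 4-chlorophenyl in place of thiophen-2-yl on a carbonyl carbon. Among the compounds with values here, no step between measured compounds is at hand, so there is nothing to lean on beyond the two values themselves. A modest move toward a lower number is expected for compound 3, with an estimated 1.3-fold lower number from compound 2 to compound 3 (0.12 log units; within the scatter). Compound 3 is thus estimated at 15000 nM, with a range from 6000 nM to 40000 nM.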

Compound 3, half-maximal effective concentration: 14000 nM
Estimate against measurement, compound 3: 1.1-fold (0.03 log units) above; low and high end bracket the measured number.
By their numbers in this assay, from the lowest: compounds 3, 2 and 1 (each within the scatter of the next).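

In this assay, within the data shown here, the exchange of thiophen-2-yl for 4-chlorophenyl on the carbonyl carbon gives a 1.4-fold lower number from compound 2 to compound 3 (0.15 log units; within the scatter) and provides the first comparison between compounds that differ in one place. At this position, one aromatic ring can therefore take the place of the other without the number leaving the usual scatter. Nothing at hand explains this result. The compounds shown leave open whether an amine, a carboxylic acid or a longer chain on that carbonyl carbon would carry the number beyond the scatter.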